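Lengthening the Alkyl Tail on the Triazole Aryl Ring

A few compounds are considered here, and "the series" means these few. Any claim that something is new, unique, unknown or untested is made for them only; others in the source may bear on it.

Compound 1 `O=c1cc(Cn2cc(CCO)nn2)c2ccc(O)cc2o1` and compound 2 `CCCCc1ccc(-c2cn(Cc3cc(=O)oc4cc(O)ccc34)nn2)cc1` share the same core and differ in what hangs from the triazole. In a functional assay on SW-620 cells (Homo sapiens) for inhibition, read by MTT assay, with a stated time of 72 h (on this read-out higher numbers stand for weaker inhibition and lower numbers for stronger inhibition), compound 1 reaches only a limit of > 100000 nM, not a number. Among the measured compounds shown here, compound 2 gives 49200 nM in this assay and therefore stands as the only real number in the set, with one of the two values sitting at the limit of > 100000 nM in this assay, at which 1 of the 2 values shown sits.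

Compound 3 `CCCCCCc1ccc(-c2cn(Cc3cc(=O)oc4cc(O)ccc34)nn2)cc1` is the next compound, differing from compound 2 by ethyl in place of hydrogen on a saturated chain carbon, four bonds along the chain from an aromatic carbon. For the measured compounds named here, no measured pair in this set carries such a lengthening, so the data give no footing for a step beyond the usual scatter in either direction. On that basis the step from compound 2 to compound 3 is expected to be small, at a 1.4-fold lower number from compound 2 to compound 3 (0.15 log units; within the scatter). Compound 3 is therefore estimated at 35000 nM, with a range from 12000 nM to 100000 nM.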

Compound 3, half-maximal inhibitory concentration: 36800 nM
Beside the measured number, compound 3's estimate is 1.1-fold (0.02 log units) below it; measured number inside the range.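

Putting ethyl in place of hydrogen on a saturated chain carbon, four bonds along the chain from an aromatic carbon, gives a 1.3-fold lower number from compound 2 to compound 3 (0.13 log units; within the scatter) in this assay. This is the only pair shown that differs in one place, and it shows that this added ethyl does not separate the two compounds on this read-out, so both remain in the same range of numbers. Nothing measured here gives a reason for this result.

As far as these compounds go, it remains open whether a longer chain, or an amine or a carboxylic acid at the end of the chain, would give a step beyond the scatter. Compound 1 gives only a limit, > 100000 nM, so it cannot show how far the number can rise when the aryl ring and its alkyl tail are absent.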